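Halogen exchange on the aryl ring: compound 2 toward compound 3

The source may report more compounds than this note shows. Statements on the series, on what has been measured and on what is new or still open speak of the compounds shown alone.

Compound 1 `O=C1/C(=C/c2ccccc2)NS(=O)(=O)c2ccccc21` gives 660 nM in an assay for inhibition of alkaline phosphatase, tissue-nonspecific isozyme (Homo sapiens), read by spectrophotometry, with stated times of 10 min and 20 min; a lower number here means a stronger inhibitor, a higher number a weaker inhibitor. Compound 2 `O=C1/C(=C/c2cccc(Cl)c2)NS(=O)(=O)c2ccccc21` carries chloro in place of hydrogen on an aromatic carbon. For compound 2 this assay reports only a limit, > 200000 nM. The step of an at least 300-fold higher number from compound 1 to compound 2 (2.48 log units; beyond the scatter) is accordingly known only as a bound, set by the limit of > 200000 nM in this assay, at which 1 of the 2 values shown sits; its true size may be larger still. Compound 2 thus stands at the weak end of the two numbers shown, with no finite value of its own.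

Compound 3 `O=C1/C(=C/c2ccc(F)cc2)NS(=O)(=O)c2ccccc21` differs from compound 2 by 4-fluorophenyl in place of 3-chlorophenyl on a double-bonded chain carbon bound to a double-bonded ring carbon. Among the measured compounds shown here, no measured step covers this exchange directly; the one step measured, an at least 300-fold higher number from compound 1 to compound 2 (2.48 log units; beyond the scatter), concerns the entry of chloro only and gives no reading on fluoro or on the other ring position. It does show that a single halogen on this ring can move the number far beyond the scatter, so a wide range is kept.

Compound 3 is estimated at 10000 nM, between 500 nM and 200000 nM. The expected step of an at least 20-fold lower number from compound 2 to compound 3 (1.30 log units; beyond the scatter) points toward a lower number, yet a result resting again at the limit remains possible.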

Compound 3, half-maximal inhibitory concentration: 1350 nM
Compound 3: the middle estimate sits 7.4-fold (0.87 log units) above what was measured; measured number inside the range.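

A halogen on this aryl ring does not by itself abolish activity in this assay: the entry of fluoro on this ring gives only a 2.0-fold higher number from compound 1 to compound 3 (0.31 log units; beyond the scatter) and stays a modest change, although it is beyond the scatter. The exchange of 3-chlorophenyl for 4-fluorophenyl gives an at least 140-fold lower number from compound 2 to compound 3 (2.17 log units; beyond the scatter) and so ties the large loss seen so far to 3-chlorophenyl, not to every halogenated phenyl among the compounds shown. Compound 2 has a limit and no finite value, so this step is known only as a bound: the limit of > 200000 nM in this assay, at which 1 of the 3 values shown sits.

The compounds shown leave open whether the identity of the halogen or its ring position carries the difference, as 3-chlorophenyl and 4-fluorophenyl differ in both, and a 4-chlorophenyl or 3-fluorophenyl group would separate the two. Also open, from the compounds shown here alone, is whether a different kind of group on this ring, such as an amine or a carboxylic acid, would give a number lower than that of compound 1 at 660 nM in this assay.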